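The compounds below may be only part of what the source reports. "The series", "measured", "known", "first", "only" and "open" are said of these compounds alone.

Compound 3 (`CCCS(=O)(=O)NCC1(C(=O)Nc2ccc(-c3ccccc3S(N)(=O)=O)cn2)CC(c2ccc(Cl)c(N)c2)=NO1`) belongs to a set of three measured compounds that share one core and differ only in the group on an amine nitrogen. In an assay on isolated protein for inhibition of serine protease 1 (Homo sapiens) (on this read-out lower numbers stand for stronger inhibition and higher numbers for weaker inhibition), compound 3 gives > 8000 nM, which is a limit of the assay and not a number. For compound 1 (`CCNC(=O)NCC1(C(=O)Nc2ccc(-c3ccccc3S(N)(=O)=O)cn2)CC(c2ccc(Cl)c(N)c2)=NO1`) this assay likewise returns only a limit, > 4200 nM. For compound 2 (`Nc1cc(C2=NOC(CNS(=O)(=O)c3cccnc3)(C(=O)Nc3ccc(-c4ccccc4S(N)(=O)=O)cn3)C2)ccc1Cl`) the assay returns a limit as well, > 8000 nM. Among the compounds with values here, the three steps between these compounds, a step that the two limits leave unreadable from compound 1 to compound 2, a step that the two limits leave unreadable from compound 1 to compound 3 and a step that the two limits leave unreadable from compound 2 to compound 3, are therefore unreadable in size; the only evidence is the limit of > 4200 nM in this assay, at which 1 of the 3 values shown sits, and (the limit of > 8000 nM in this assay, at which 2 of the 3 values shown sit).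

Compound 4 (`Nc1cc(C2=NOC(CNS(=O)(=O)c3ccsc3)(C(=O)Nc3ccc(-c4ccccc4S(N)(=O)=O)cn3)C2)ccc1Cl`) departs from compound 3 by thiophen-3-yl in place of propyl on a sulfonyl sulfur. Within the data shown here, no measured step bears on this change in a readable way, and the three limits offer no direction. Compound 4 is therefore expected to sit again at or beyond the limit, with a step that the limit leaves unreadable from compound 3 to compound 4 expected to be no step beyond the scatter. The estimate for compound 4 in this assay is 10000 nM, with a range from 4000 nM to 30000 nM.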

Compound 4, inhibition constant: > 8000 nM
Compound 4: no number, only a limit; the forecaster's own chance of this, stated with the estimate: 80%; the middle value is on the limit's open side.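

In this assay compound 4 gives > 8000 nM as a limit of the assay and not a number, so its steps from compound 1, compound 2 and compound 3 cannot be read. In this assay the compounds shown leave open whether changing the group on the amine nitrogen alters inhibition at all.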